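Para-chloro on the anilide: expecting a large potency gain

The compounds below may be only part of what the source reports. "The series", "measured", "known", "first", "only" and "open" are said of these compounds alone.

Compound 1 `O=C(Nc1ccc(F)cc1F)c1cncc(N2CC3CC(C2)N3)c1`: 0.051 nM
Compound 2 `O=C(Nc1ccc(F)cc1)c1cncc(N2CC3CC(C2)N3)c1`: 0.01 nM
Compound 3 `O=C(Nc1ccccc1)c1cncc(N2CC3CC(C2)N3)c1`: 1.1 nM

Three compounds share one core and differ only in the ring attached to the amide nitrogen, all measured in an assay on membranes from Cerebral cortex for displacement of a labelled ligand from Neuronal acetylcholine receptor; alpha4/beta2 (Rattus norvegicus); a lower number here means a stronger inhibitor, a higher number a weaker inhibitor. Compound 3, the plain phenyl, gives the highest number of the three: a 22-fold higher number from compound 1 to compound 3 (1.33 log units; beyond the scatter) and a 110-fold higher number from compound 2 to compound 3 (2.04 log units; beyond the scatter). Compound 4 `O=C(Nc1ccc(Cl)cc1)c1cncc(N2CC3CC(C2)N3)c1` arises from compound 3 by chloro in place of hydrogen on an aromatic carbon. The step that bears most directly on this is the reverse of a 110-fold higher number from compound 2 to compound 3 (2.04 log units; beyond the scatter), where the same ring position carried fluoro instead of hydrogen. A halogen at that position therefore is expected to lower the number strongly, an estimated 22-fold lower number from compound 3 to compound 4 (1.34 log units; beyond the scatter). Compound 4 is estimated at 0.05 nM, within a range from 0.008 nM to 0.4 nM.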

Compound 4, inhibition constant: 0.404 nM
Compound 4: the middle estimate sits 8.1-fold (0.91 log units) below what was measured; the measured number lies above the stated range.
By their numbers in this assay, from the lowest: compound 2; then compound 1; then compound 4; then compound 3.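

Chloro at this position, para to a large group, still lowers the number (a 2.7-fold lower number from compound 3 to compound 4 (0.44 log units; beyond the scatter)), so fluoro is not the only halogen tolerated there. The two halogens are far from interchangeable, though: swapping fluoro for chloro raises the number sharply (a 40-fold higher number from compound 2 to compound 4 (1.61 log units; beyond the scatter)), and compound 4 also stands weaker than the difluorinated ring (a 7.9-fold higher number from compound 1 to compound 4 (0.90 log units; beyond the scatter)). No measurement shown here accounts for the gap between chloro and fluoro. Still open, on these data alone, is how a bromo, methyl or methoxy group at this position would compare with these two halogens.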